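This account rests on a few compounds, and the source may have more. Where it says the series, first, only, none or still open, it means among the compounds named here.

Measured in a functional assay on M21 cells (Homo sapiens) for antiproliferative activity, read by sulforhodamine B assay, with a stated time of 48 h; on this read-out lower numbers stand for stronger inhibition and higher numbers for weaker inhibition:
- compound 1 `CN1CCN(c2ccc(S(=O)(=O)Oc3cccc(F)c3)cc2)C1=O`: 5800 nM
- compound 2 `CN1CCN(c2ccc(S(=O)(=O)Oc3cccc([N+](=O)[O-])c3)cc2)C1=O`: 23000 nM
- compound 3 `COc1cc(OS(=O)(=O)c2ccc(N3CCN(C)C3=O)cc2)cc(OC)c1OC`: 54 nM

Compound 1 sits in the middle of these three numbers, with compound 2 higher and compound 3 far lower. Compound 4 `COc1ccc(OS(=O)(=O)c2ccc(N3CCN(C)C3=O)cc2)cc1` has not been measured yet. It keeps the core of compound 1 but carries 4-methoxyphenyl in place of 3-fluorophenyl on an oxygen. Within the data shown here, one measured step bears on this, a 4.0-fold higher number from compound 1 to compound 2 (0.60 log units; beyond the scatter), where nitro replaces fluoro and the number moves modestly. Compound 3, which also carries methoxy groups, gives 54 nM, so a move to a lower number in this assay is expected, covering only part of that gap. The expected change is a 3.9-fold lower number from compound 1 to compound 4 (0.59 log units; beyond the scatter). For compound 4 the estimate is 1500 nM, with an expected range from 300 nM to 6000 nM.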

Compound 4, half-maximal inhibitory concentration: > 100000 nM
Compound 4: no number, only a limit; the forecaster's own chance of this, stated with the estimate: 3%; middle value at least 66-fold (1.82 log units) away from the limit.
By their numbers in this assay, from the lowest: compound 3; then compound 1; then compound 2. At a limit, above all of these: compound 4.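

In this assay, changing the aromatic group on this oxygen can do far more than shift the number modestly, giving an at least 17-fold higher number from compound 1 to compound 4 (1.23 log units; beyond the scatter). The result for compound 4 is a limit of the assay, not a number: the limit of > 100000 nM in this assay, at which 1 of the 4 values shown sits. Methoxy alone does not bring strength here: compound 3, which carries methoxy groups, gives 54 nM. Still open, on these data alone, is whether the loss follows from gaining the methoxy group or from losing the fluoro group. As far as these compounds go, how a phenyl ring carrying an amine would behave on this oxygen also stays open.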